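The source may report more compounds than this note shows. Statements on the series, on what has been measured and on what is new or still open speak of the compounds shown alone.

Compound 1 `CC(C)CCN1C(=O)C(C2=NS(=O)(=O)c3cc(NS(C)(=O)=O)ccc3N2)=C(O)C2CCCC21`: 0.167 h
Compound 2 `CC(C)CCN1C(=O)C(C2=NS(=O)(=O)c3cc(NS(C)(=O)=O)ccc3N2)=C(O)[C@H]2CCC[C@H]21`: 0.383 h

In an in vitro ADME assay on microsomes from liver (Homo sapiens) for metabolic stability (on this read-out lower numbers stand for a shorter-lived compound and higher numbers for a longer-lived compound), compound 2 has the higher of the two numbers, at 0.383 h. Compound 3 `CS(=O)(=O)Nc1ccc2c(c1)S(=O)(=O)N=C(C1=C(O)[C@H]3CCC[C@H]3N(Cc3cccc(C(F)(F)F)c3)C1=O)N2` keeps the shared core and changes only the side chain: 3-(trifluoromethyl)phenyl in place of isobutyl on a saturated chain carbon bound to an amide-type nitrogen in a ring. Within the data shown here, the only measured step, a 2.3-fold higher number from compound 1 to compound 2 (0.36 log units; beyond the scatter), concerns (the fact that one of compounds 1 and 2 is drawn with a defined configuration and the other without, at the place where they differ), not this side chain, so it offers a sense of scale but no direction. Among the measured compounds shown here, no measured compound carries the new group, so the expected step is tentative: a modest rise, a 2.1-fold higher number from compound 2 to compound 3 (0.32 log units; beyond the scatter). For compound 3 the estimate is 0.8 h, with an expected range of 0.25 h to 2.5 h.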

Compound 3, half-life: > 1 h
Compound 3: no number, only a limit; the forecaster's own chance of this, stated with the estimate: 5%; at least 1.2-fold (0.09 log units) between middle value and limit.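

In this assay compound 3 gives > 1 h, which is a limit of the assay and not a number. Putting 3-(trifluoromethyl)phenyl in place of isobutyl gives an at least 2.6-fold higher number from compound 2 to compound 3 (0.41 log units; beyond the scatter), so the side chain alone can shift this read-out beyond the scatter, and an aromatic ring at this position goes with a longer-lived compound. Nothing measured here gives a reason for this rise.

The compounds shown do not separate the contribution of the aromatic ring from that of the trifluoromethyl group. From the compounds shown here alone, a plain benzyl would address that, while a side chain ending in an amine or a carboxylic acid remains unexplored.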